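The compounds below may be only part of what the source reports. "The series", "measured", "known", "first", "only" and "open" are said of these compounds alone.

Measured so far in a functional assay on MIA PaCa-2 cells (Homo sapiens) for inhibition, read by MTT assay, with a stated time of 7 days; on this read-out higher numbers stand for weaker inhibition and lower numbers for stronger inhibition:

Compound 1, `CC(C)c1noc(N2CCN(C(=O)[C@@H]3CCCN(S(=O)(=O)c4ccc(S(=O)(=O)C5CCC5)cc4)C3)CC2)n1`: compound 1 gives 70 nM.
Compound 2, `CC(C)c1noc(N2CCN(C(=O)[C@@H]3CCCN(S(=O)(=O)c4ccc(S(=O)(=O)C(C)C)cc4)C3)CC2)n1`: compound 2 gives 70 nM.
Compound 3, `CC(C)c1noc(N2CCN(C(=O)[C@@H]3CCCN(S(=O)(=O)c4ccc(S(=O)(=O)NC5CCC5)cc4)C3)CC2)n1`: compound 3 gives 600 nM.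

Compound 3 stands highest of the three numbers, which on this read-out means the weakest inhibition of the three: the steps of an 8.6-fold higher number from compound 1 to compound 3 (0.93 log units; beyond the scatter) and an 8.6-fold higher number from compound 2 to compound 3 (0.93 log units; beyond the scatter) both lie beyond the scatter. Compound 4, `CCNS(=O)(=O)c1ccc(S(=O)(=O)N2CCC[C@@H](C(=O)N3CCN(c4nc(C(C)C)no4)CC3)C2)cc1`, differs from compound 3 in one place: ethyl in place of cyclobutyl on a sulfonamide nitrogen. The measured step that bears most closely on this change is no change at the digits printed from compound 1 to compound 2 (within the scatter), where cyclobutyl gave way to isopropyl on a sulfonyl sulfur and the number did not move beyond the scatter. The other two steps describe the arrival of the sulfonamide nitrogen itself, which compound 4 keeps, so they say nothing about swapping one small alkyl group for another on that nitrogen. Among the measured compounds shown here, on the single comparable step, the expectation for compound 4 is no change beyond the scatter, no change at the digits printed from compound 3 to compound 4 (within the scatter). The estimate for compound 4 in this assay is therefore 600 nM, with a range from 250 nM to 1500 nM.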

Compound 4, half-maximal inhibitory concentration: 3300 nM
Compound 4: middle estimate off by 5.5-fold (0.74 log units), on the low side; measured number above the stated range.
By their numbers in this assay, from the lowest: compounds 1 and 2 (each within the scatter of the next); then compound 3; then compound 4.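

In this assay, the sulfonamide nitrogen proves sensitive to its alkyl group: ethyl in place of cyclobutyl gives a 5.5-fold higher number from compound 3 to compound 4 (0.74 log units; beyond the scatter) as its step, whereas isopropyl in place of cyclobutyl on a sulfonyl sulfur gave no change at the digits printed from compound 1 to compound 2 (within the scatter) as its step. Replacing the carbon groups on that sulfur with ethylamino also gives larger steps, a 47-fold higher number from compound 2 to compound 4 (1.67 log units; beyond the scatter) and a 47-fold higher number from compound 1 to compound 4 (1.67 log units; beyond the scatter), than the step with cyclobutylamino, an 8.6-fold higher number from compound 1 to compound 3 (0.93 log units; beyond the scatter) in the same assay. Nothing given here accounts for these differences.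

With only cyclobutyl and ethyl on this nitrogen, it remains unclear whether the ring itself or the number of carbons matters more. Isopropyl on the same nitrogen could help separate the two, and a bare amino group or a longer chain such as butyl would show how far the trend extends.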